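Amide aryl to benzyl swap in one series

A few compounds are considered here, and "the series" means these few. Any claim that something is new, unique, unknown or untested is made for them only; others in the source may bear on it.

The compounds share one core and differ only at the amide nitrogen. Compound 1 `COc1ccc2c(=O)c(/C=C/C(=O)Nc3ccc(C)cc3)coc2c1` gives 17500 nM in a functional assay on A549 cells (Homo sapiens) for inhibition, read by MTT assay, with a stated time of 48 h; a higher number here means a weaker inhibitor, a lower number a stronger inhibitor. Compound 3 `COc1ccc(CNC(=O)/C=C/c2coc3cc(OC)ccc3c2=O)cc1` gives 22500 nM in this assay. For compound 2 `COc1ccc2c(=O)c(/C=C/C(=O)Nc3ccc(Cl)cc3)coc2c1` this assay reports only a limit, > 100000 nM. Of the two numbers, compound 1 stands lowest, with compound 3 nearest at a 1.3-fold higher number from compound 1 to compound 3 (0.11 log units; within the scatter); the third value is a limit (the limit of > 100000 nM in this assay, at which 1 of the 3 values shown sits). The step of an at least 5.7-fold higher number from compound 1 to compound 2 (0.75 log units; beyond the scatter) lies beyond the scatter, as does an at least 4.4-fold lower number from compound 2 to compound 3 (0.64 log units; beyond the scatter).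

Compound 4 `COc1ccc2c(=O)c(/C=C/C(=O)NCc3ccc(C)cc3)coc2c1` is not yet measured. Its change from compound 1 is 4-methylbenzyl in place of 4-methylphenyl on an amide-type nitrogen. The closest measured step, which replaces the same 4-methylphenyl with 4-methoxybenzyl, is a 1.3-fold higher number from compound 1 to compound 3 (0.11 log units; within the scatter), within the scatter. The chloro step an at least 5.7-fold higher number from compound 1 to compound 2 (0.75 log units; beyond the scatter) does not bear on an exchange of a phenyl for a benzyl group. No step beyond the scatter is therefore expected in this assay, in either direction. Compound 4 is expected at 20000 nM, between 8000 nM and 50000 nM. That estimate means a 1.1-fold higher number from compound 1 to compound 4 (0.06 log units; within the scatter), expected to stay within the scatter.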

Compound 4, half-maximal inhibitory concentration: > 100000 nM
Compound 4: only a limit was reported (the forecaster's own chance of this, stated with the estimate: 10%); at least 5.0-fold (0.69 log units) between middle value and limit.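

On the amide-type nitrogen, a benzyl group is not interchangeable with an aryl group as such in this assay: 4-methylbenzyl in place of 4-methylphenyl gives an at least 5.7-fold higher number from compound 1 to compound 4 (0.75 log units; beyond the scatter), whereas the 4-methoxybenzyl of compound 3 stayed within the scatter of compound 1. The group carried on the benzyl ring therefore counts, since methyl in place of methoxy on an aromatic carbon gives an at least 4.4-fold higher number from compound 3 to compound 4 (0.64 log units; beyond the scatter). Compound 4 and compound 2 are both reported only as limits, so the step that joins them cannot be read: the limit of > 100000 nM in this assay, at which 2 of the 4 values shown sit.

On these data alone, whether methoxy is unusual in keeping a measurable number remains open, as an amine or a carboxylic acid in its place on the aromatic carbon could read either way. Also open, as far as these compounds go, is whether a phenethyl group on the amide-type nitrogen would read like compound 3 or compound 4.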